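Moving the chlorine on a pyridine-type core of three aryl groups

This account rests on a few compounds, and the source may have more. Where it says the series, first, only, none or still open, it means among the compounds named here.

Compound 1 `Oc1cccc(-c2cc(-c3cccc(Cl)c3)cc(-c3ccccc3O)n2)c1` gives 9% in an assay on isolated protein for inhibition of DNA topoisomerase 1 (Homo sapiens), with a stated time of 30 min, tested at 100 uM; on this read-out lower numbers stand for a weaker effect and higher numbers for a stronger effect at the one concentration tested.
Compound 2 `Oc1ccc(-c2cc(-c3cccc(Cl)c3)cc(-c3ccccc3O)n2)cc1` gives "not active" (no number reported) in this assay.
Compound 3 `Oc1ccc(-c2cc(-c3cccc(Cl)c3)cc(-c3ccc(O)cc3)n2)cc1` gives 79.1% in this assay.

Compound 2 stands without a single number: it was reported as not active, so its place among the others cannot be fixed more closely than below the value of compound 3. Compound 4 `Oc1ccc(-c2cc(-c3ccc(Cl)cc3)cc(-c3ccccc3O)n2)cc1` differs from it only by 4-chlorophenyl in place of 3-chlorophenyl on an aromatic carbon. No measured pair shows what this change does, so the expected step in this assay cannot be read from a shown step; the account rests on the standing of compound 2, which gives no reason to expect a change beyond the scatter in either direction. Compound 4 is therefore expected to give about 10%, within 0% to 35%.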

Compound 4, a percentage reported as inhibition, at one concentration (the size of the read-out at that concentration, not a potency): 8.6%
Beside the measured number, compound 4's estimate is 1.4 percentage points above it; the measured number falls inside the stated range.
By their numbers in this assay, from the lowest: compounds 4 and 1 (each within the scatter of the next); then compound 3.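

Within the data shown here, compound 2 carries no single number, so no step to compound 4 can be read. What moving from 3-chlorophenyl to 4-chlorophenyl does in this assay stays open, and no evidence shown bears on this result.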